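This account rests on a few compounds, and the source may have more. Where it says the series, first, only, none or still open, it means among the compounds named here.

Compound 1 `Nc1nc(Cl)c2ncn(Cc3ccccc3CCl)c2n1` gives 7410 nM in a functional assay on SF-295 cells (Homo sapiens) for cytotoxicity, read by sulforhodamine B assay, with a stated time of 48 h; on this read-out higher numbers stand for weaker inhibition of growth and lower numbers for stronger inhibition of growth; compound 2 `ClCc1cccc(Cn2cnc3nc(Cl)nc(Cl)c32)c1` gives 1860 nM.

Compound 1 stands highest of the two numbers measured; compound 2 shows a lower number, and the two values differ by more than the usual scatter. Compound 3 `ClCc1ccccc1Cn1cnc2c(Cl)nc(Cl)nc21` is not yet measured. It arises from compound 1 by chloro in place of amino on an aromatic carbon. Among the compounds with values here, no step between measured compounds accompanies this change. Compound 3 is expected to give a lower number than compound 1, a step of a 3.0-fold lower number from compound 1 to compound 3 (0.47 log units; beyond the scatter), beyond the scatter. Compound 3 is estimated at 2500 nM, with a range from 800 nM to 8000 nM.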

Compound 3, concentration for 50% growth inhibition: 1900 nM
Beside the measured number, compound 3's estimate is 1.3-fold (0.12 log units) above it; measured number inside the range.
By their numbers in this assay, from the lowest: compounds 2 and 3 (each within the scatter of the next); then compound 1.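

In this assay, chloro in place of amino on the aromatic carbon between two ring nitrogen atoms gives a 3.9-fold lower number from compound 1 to compound 3 (0.59 log units; beyond the scatter), so this position is not indifferent to the group it carries. This is the only single-place change among these compounds, and it swaps an amino group, counted with one hydrogen-bond donor and one acceptor, for a chloro group counted with neither. Nothing available explains the size of this step. Going by these compounds, whether a methoxy group or a dimethylamino group here would read closer to chloro or to amino stays open, as does whether a bromo group would match chloro.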